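The source may report more compounds than this note shows. Statements on the series, on what has been measured and on what is new or still open speak of the compounds shown alone.

Compound 1 `Cc1c(C)c2c(c(C)c1N)CC(C)(CSc1ccc(O)cc1)O2` gives > 50 mg/kg in a functional assay on the whole organism with Mus musculus as the target (on this read-out higher numbers stand for an effect only at larger amounts of compound and lower numbers for an effect already at smaller amounts), which is a limit of the assay and not a number. Going by the values given here, compound 2 `Cc1c(C)c2c(c(C)c1N)CC(C)(CSc1ccncc1)O2` gives 19.9 mg/kg in this assay, the only actual number so far.

Compound 3 `Cc1c(C)c2c(c(C)c1N)CC(C)(CSCc1ccccc1)O2` carries a new group on the same sulfur, with benzyl in place of pyridin-4-yl on a sulfur.

Among the compounds with values here, only one measured step bears on this change: an at least 2.5-fold lower number from compound 1 to compound 2 (0.40 log units; beyond the scatter), with pyridin-4-yl in place of 4-hydroxyphenyl on a sulfur. From the compounds shown here alone, one end of that step rests on (the limit of > 50 mg/kg in this assay, at which 1 of the 2 values shown sits), so its full size is unknown. Compound 3 gives up pyridin-4-yl for a six-membered aromatic ring of carbon only, and compound 1 also has a ring of carbon only. On the strength of an at least 2.5-fold lower number from compound 1 to compound 2 (0.40 log units; beyond the scatter), a move back towards a higher number is expected, though benzyl itself has not been tested and the evidence is thin.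

In this assay the expected step is a 2.0-fold higher number from compound 2 to compound 3 (0.30 log units; within the scatter), a small to modest one. For compound 3 the estimate is 40 mg/kg, with an expected range of 15 mg/kg to 90 mg/kg.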

Compound 3, dose for 50% inhibition: 32 mg/kg
Estimate against measurement, compound 3: 1.3-fold (0.10 log units) above; measured number inside the range.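

In this assay, the change from pyridin-4-yl to benzyl on the sulfur gives a 1.6-fold higher number from compound 2 to compound 3 (0.21 log units; within the scatter), so the two groups cannot be told apart, and the ring nitrogen of compound 2 is not needed for a dose in this range: compound 3, with a six-membered aromatic ring of carbon only, also reaches a number. The earlier pair left open whether a ring of carbon only would always read like compound 1, and compound 3 shows that it need not, although benzyl in place of 4-hydroxyphenyl gives only an at least 1.5-fold lower number from compound 1 to compound 3 (0.19 log units; that floor lies within the scatter). Compound 1 stands at > 50 mg/kg, which is a limit and not a number, so that step has a floor and no full size: the limit of > 50 mg/kg in this assay, at which 1 of the 3 values shown sits.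

From the compounds shown here alone, compound 3 differs from compound 1 in both the hydroxyl and the extra chain carbon, so it remains open which of the two matters, and plain phenyl or 4-hydroxybenzyl on the sulfur would separate them. Going by these compounds, how a longer chain such as phenethyl, or a group carrying an amine or a carboxylic acid, would read at this sulfur also remains open.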